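Dropping the Drawn Configuration at the Chain Stereocentre

The source may report more compounds than this note shows. Statements on the series, on what has been measured and on what is new or still open speak of the compounds shown alone.

Measured in a functional assay on HCT-116 cells (Homo sapiens) for antiproliferative activity, read by MTT assay, with a stated time of 48 h; a higher number here means a weaker inhibitor, a lower number a stronger inhibitor:
- compound 1 `CCCCCCCCCC(CCN=[N+]=[N-])n1cnc2c(Cl)ncnc21`: 1040 nM
- compound 2 `CCCCCCCCC[C@H](CCn1cc(-c2ccccc2)nn1)n1cnc2c(Cl)ncnc21`: 8130 nM

Compound 2 stands at the higher number of the two, 8130 nM, against compound 1 at 1040 nM. The gap between the two lies beyond the scatter. Compound 3 `CCCCCCCCCC(CCn1cc(-c2ccccc2)nn1)n1cnc2c(Cl)ncnc21` is the next to be considered, and it differs from compound 2 in one way: the two compounds have the same atoms and bonds; at least one stereo element is drawn with a configuration in one of them and without one in the other: 1 of 1 stereo elements differ; a stereocentre at a saturated chain carbon is drawn R in compound 2 and without a configuration in compound 3. Within the data shown here, no measured pair shows what such a change does in this assay. With atoms and bonds unchanged from compound 2 at 8130 nM, little movement is expected. The expected change is a 1.3-fold lower number from compound 2 to compound 3 (0.10 log units; within the scatter), slightly toward a lower number and not beyond the scatter. For compound 3 the estimated value is 6500 nM, with an expected range of 2800 nM to 13000 nM.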

Compound 3, half-maximal inhibitory concentration: 13500 nM
For compound 3 the middle estimate is 2.1-fold (0.32 log units) below the measured one, outside the stated range (above it).
By their numbers in this assay, from the lowest: compound 1; then compounds 2 and 3 (each within the scatter of the next).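

In this assay, removing the drawn configuration at the chain stereocentre gives a 1.7-fold higher number from compound 2 to compound 3 (0.22 log units; within the scatter), so this assay does not separate the form drawn R from the form drawn without a configuration. Placing 4-phenyl-1H-1,2,3-triazol-1-yl in place of azido on the saturated chain carbon gives a 13-fold higher number from compound 1 to compound 3 (1.11 log units; beyond the scatter), a large step now read without a drawn configuration on either side. The first pair differs only in how it is drawn: the fact that one of compounds 2 and 3 is drawn with a defined configuration and the other without, at the place where they differ

The compounds shown leave open how the S form would compare. They also leave open where an amine in place of azido, or a carboxylic acid in place of the phenyl on the triazole, would fall.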